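Phenoxy for Phenylethenyl at the Meta Position

The source may report more compounds than this note shows. Statements on the series, on what has been measured and on what is new or still open speak of the compounds shown alone.

Compound 1 `C=C(c1ccccc1)c1ccc(N(Cc2cccnc2)S(=O)(=O)CC)cc1`: 780 nM
Compound 2 `C=C(c1ccccc1)c1cccc(N(Cc2cccnc2)S(=O)(=O)CC)c1`: 200 nM
Compound 3 `CCS(=O)(=O)N(Cc1cccnc1)c1ccc(C(C)c2ccccc2)cc1`: 1400 nM

In an assay on isolated protein with metabotropic glutamate receptor 2 (Homo sapiens) as the target (on this read-out higher numbers stand for an effect only at larger amounts of compound and lower numbers for an effect already at smaller amounts), compound 2 gives the lowest of the three numbers, the value of compound 1 lying clearly higher and that of compound 3 higher still. Compound 4 `CCS(=O)(=O)N(Cc1cccnc1)c1cccc(Oc2ccccc2)c1` differs from compound 2 by phenoxy in place of 1-phenylethenyl on an aromatic carbon. Going by the values given here, only one measured step touches the 1-phenylethenyl group: a 1.8-fold higher number from compound 1 to compound 3 (0.25 log units; within the scatter), a change at a different place on the core and of a different kind. Among the compounds with values here, no measured step exchanges this group for phenoxy. The step to compound 4 is therefore expected to be modest, most likely toward a higher number, a 2.0-fold higher number from compound 2 to compound 4 (0.30 log units; within the scatter). Compound 4 is estimated at 400 nM, within 130 nM to 1300 nM.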

Compound 4, half-maximal effective concentration: 360 nM
Compound 4: middle estimate off by 1.1-fold (0.05 log units), on the high side; low and high end bracket the measured number.
By their numbers in this assay, from the lowest: compounds 2 and 4 (each within the scatter of the next); then compounds 1 and 3 (each within the scatter of the next).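

In this assay, replacing 1-phenylethenyl with phenoxy gives a 1.8-fold higher number from compound 2 to compound 4 (0.26 log units; within the scatter). The earlier compounds shown here showed only an alteration of the 1-phenylethenyl group at a different place on the core, whereas here the whole group is exchanged on an aromatic carbon, meta to a large group. The double bond outside aromatic rings leaves and one oxygen enters, yet the step stays within the scatter.

On these data alone, it remains open whether benzoyl or anilino would fit this place equally well, and how phenoxy would read at the place the group occupies in compound 1. Nothing available gives a reason for this outcome.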